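A few compounds are considered here, and "the series" means these few. Any claim that something is new, unique, unknown or untested is made for them only; others in the source may bear on it.

Series notes. Compound 1 `COc1ccc(C(=O)/C=C/c2nc3ccccc3cc2-c2ccc(OC)cc2)cc1` and compound 2 `COc1ccc(-c2cc3ccccc3nc2/C=C/C(=O)c2ccc(N)cc2)cc1` share one core and differ only at the aryl ketone. In a functional assay on SK-BR-3 cells (Homo sapiens) for antiproliferative activity, read by XTT assay, with a stated time of 72 h (on this read-out higher numbers stand for weaker inhibition and lower numbers for stronger inhibition), compound 1 gives 9280 nM and compound 2 gives 8560 nM; compound 2 holds the lower of the two numbers, but a 1.1-fold lower number from compound 1 to compound 2 (0.04 log units; within the scatter), so no order between them is claimed. Compound 3 `COc1ccc(-c2cc3ccccc3nc2/C=C/C(=O)c2ccc[nH]2)cc1` changes the same ketone aryl: 1H-pyrrol-2-yl in place of 4-aminophenyl on a carbonyl carbon. Within the data shown here, no measured step covers an aromatic ring swap at the carbonyl carbon; the one step known, from 1 to 2, lies within the scatter, so no shift beyond the scatter is expected for compound 3, i.e. a 1.1-fold higher number from compound 2 to compound 3 (0.05 log units; within the scatter). The estimate for compound 3 is 9500 nM, range 3000 nM to 30000 nM.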

Compound 3, half-maximal inhibitory concentration: > 10000 nM
Compound 3 was reported as a limit; the forecaster's own chance of this, stated with the estimate: 15%; at least 1.0-fold (0.02 log units) between middle value and limit.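

Among these compounds, compound 3 stands in this assay only as a limit, > 10000 nM, so this is the first ketone aryl at this position without a number: the limit of > 10000 nM in this assay, at which 1 of the 3 values shown sits. Swapping the six-membered ring for 1H-pyrrol-2-yl on the carbonyl carbon gives an at least 1.1-fold higher number from compound 2 to compound 3 (0.06 log units; that floor lies within the scatter), and the comparison with the methoxy compound gives an at least 1.0-fold higher number from compound 1 to compound 3 (0.03 log units; that floor lies within the scatter). Neither floor supports a claimed loss, though the true size of each step could be larger.

On these data alone, how far compound 3 lies past its limit stays open. So does whether a carboxylic acid or a longer chain at this carbonyl carbon would move the number beyond the scatter.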